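Dimethylamino in place of acetyl: what to expect

A few compounds are considered here, and "the series" means these few. Any claim that something is new, unique, unknown or untested is made for them only; others in the source may bear on it.

Measured compounds:
Compound 1, `COc1cc(C)cc(-c2c(-c3ccnc(-c4ccc(C(C)=O)cc4)c3)cnn2CC#N)c1`: in a functional assay on SF-268 cells (Homo sapiens) for inhibition, read by sulforhodamine B assay, with a stated time of 48 h (on this read-out lower numbers stand for stronger inhibition of growth and higher numbers for weaker inhibition of growth), compound 1 gives > 100000 nM, which is a limit of the assay and not a number.
Compound 2, `COc1cc(C)cc(-c2nn(CC#N)cc2-c2ccc(-c3cccc(C(C)=O)c3)nc2)c1`: in this assay compound 2 gives 81400 nM.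
Compound 3, `Cc1cc(O)cc(-c2nn(CC#N)cc2-c2ccnc(-c3ccc(N(C)C)cc3)c2)c1`: in this assay compound 3 gives 16900 nM.

Compound 1 stands at the edge of what the assay reports: the limit of > 100000 nM in this assay, at which 1 of the 3 values shown sits. Within the data shown here, of the three measured compounds it is the only one without a number, so nothing can be said about how far beyond that limit it lies. Compound 2 and compound 3 both give numbers, and the value of compound 3 is the lower of the two.

Compound 4, `COc1cc(C)cc(-c2c(-c3ccnc(-c4ccc(N(C)C)cc4)c3)cnn2CC#N)c1`, has not yet been measured. It differs from compound 1 in a single place: dimethylamino in place of acetyl on an aromatic carbon. Among the measured compounds shown here, compound 3 carries the same dimethylamino group on its outer ring, but compound 3 also differs from compound 1 elsewhere, so no single step connects compound 3 to either compound 1 or compound 4.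

Because compound 1 gives only a limit, the step from compound 1 to compound 4 can at best be estimated, and it is expected to move toward stronger growth inhibition by an at least 2.5-fold lower number from compound 1 to compound 4 (0.39 log units; beyond the scatter), beyond the usual scatter. The estimated value for compound 4 is 40000 nM, with a range from 10000 nM to 150000 nM.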

Compound 4, concentration for total growth inhibition: > 100000 nM
Compound 4: only a limit was reported; the forecaster's own chance of this, stated with the estimate: 30%; middle value at least 2.5-fold (0.39 log units) away from the limit.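

In this assay compound 4 gives > 100000 nM, which is a limit of the assay and not a number. Compound 1 also stands at a limit, so no step can be read between compound 1 and compound 4: the limit of > 100000 nM in this assay, at which 2 of the 4 values shown sit. The compounds shown leave open whether dimethylamino in place of acetyl changes growth inhibition at all.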